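Ethoxy for methoxy on the anilide and the free aniline

A few compounds are considered here, and "the series" means these few. Any claim that something is new, unique, unknown or untested is made for them only; others in the source may bear on it.

Compound 1 `C=C(Br)C(=O)Nc1ccc(/C=C/C(=O)c2ccc(OC)cc2)cc1` and compound 2 `C=C(Br)C(=O)Nc1ccc(/C=C/C(=O)c2ccc(OCC)cc2)cc1` differ by methyl in place of hydrogen on a saturated chain carbon bound to an oxygen on an aromatic ring. In an ADME assay on CCRF-CEM cells (Homo sapiens) for antiproliferative activity, with a stated time of 48 h (on this read-out lower numbers stand for stronger inhibition and higher numbers for weaker inhibition), compound 1 gives 1400 nM and compound 2 gives 750 nM, a step of a 1.9-fold lower number from compound 1 to compound 2 (0.27 log units; within the scatter). Compound 3 `COc1ccc(C(=O)/C=C/c2ccc(N)cc2)cc1` shares the core of compound 1 except for (hydrogen in place of (1-bromoethenyl)carbonyl on a nitrogen on an aromatic ring); in this assay compound 3 gives 37000 nM, which is a 26-fold higher number from compound 1 to compound 3 (1.42 log units; beyond the scatter). Compound 4 `CCOc1ccc(C(=O)/C=C/c2ccc(N)cc2)cc1` is not yet measured. It differs from compound 3 by methyl in place of hydrogen on a saturated chain carbon bound to an oxygen on an aromatic ring, the same change that was made from compound 1 to compound 2, at the same kind of place, so the pair of compounds 3 and 4 repeats the earlier pair on the core that lacks the acyl group. Within the data shown here, only one measured example of this change exists, and it lies within the scatter, so a small step is expected here as well. The step from compound 3 to compound 4 is estimated at a 1.5-fold lower number from compound 3 to compound 4 (0.17 log units; within the scatter), resting on the earlier 1.9-fold lower number from compound 1 to compound 2 (0.27 log units; within the scatter) and on compound 3 standing at 37000 nM. Compound 4 is expected to give 25000 nM, with a likely range from 11000 nM to 70000 nM.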

Compound 4, half-maximal inhibitory concentration: 15000 nM
Compound 4: the middle estimate sits 1.7-fold (0.22 log units) above what was measured, within the range that was stated.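

In this assay, among these compounds, ethoxy for methoxy on the free aniline gives a 2.5-fold lower number from compound 3 to compound 4 (0.39 log units; beyond the scatter), a step that agrees with the one on the core carrying the acyl group: the same change on two cores in this assay, a 1.9-fold lower number (0.27 log units; within the scatter) from compound 1 to compound 2 and a 2.5-fold lower number (0.39 log units; beyond the scatter) from compound 3 to compound 4, 1.3-fold (0.12 log units) apart, within the scatter of two such steps Removing the (1-bromoethenyl)carbonyl group from the ethoxy compound gives a 20-fold higher number from compound 2 to compound 4 (1.30 log units; beyond the scatter), which agrees with the same removal in the methoxy pair: the same change on two cores in this assay, a 26-fold higher number (1.42 log units; beyond the scatter) from compound 1 to compound 3 and a 20-fold higher number (1.30 log units; beyond the scatter) from compound 2 to compound 4, 1.3-fold (0.12 log units) apart, within the scatter of two such steps Across these four compounds, each change therefore carries from one core to the other with no difference beyond the scatter, but each comparison rests on only two steps, and this does not show that either change would carry to other cores or other assays.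

The compounds shown leave open whether a longer chain, such as propoxy, or a branched chain, such as isopropoxy, would continue the step seen with ethoxy. They also leave open whether another acyl group on the nitrogen, such as plain acetyl or acryloyl without the bromine, would give numbers close to those of the bromo amides.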